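Indole series: bromo replaced by methyl on the benzyl ring

A few compounds are considered here, and "the series" means these few. Any claim that something is new, unique, unknown or untested is made for them only; others in the source may bear on it.

Three members of the series carry a measurement. In a functional assay on NCI-H460 cells (Homo sapiens) for cytotoxicity, read by sulforhodamine B assay, with a stated time of 3 days (on this read-out higher numbers stand for weaker inhibition and lower numbers for stronger inhibition), compound 1 `OCc1cn(Cc2cccc(Br)c2)c2ccccc12` gives 28 nM. Compound 3 `Cc1cccc(Cn2cc(CO)c3ccccc32)c1` gives 31 nM in this assay, and compound 2 `OCc1cn(Cc2ccc(Br)cc2)c2ccccc12` gives 31 nM in this assay. Compound 2 and compound 3 stand level at the digits printed, and the values of compound 1 and compound 2 lie within the scatter of each other.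

One change is measured directly: methyl in place of bromo on an aromatic carbon, which gave a 1.1-fold higher number from compound 1 to compound 3 (0.04 log units; within the scatter). Compound 1 and compound 2 have the same atoms joined differently; the difference between the two cores is not broken down here.

Compound 4 `Cc1ccc(Cn2cc(CO)c3ccccc32)cc1` has not been measured. It differs from compound 2 by methyl in place of bromo on an aromatic carbon. Among the compounds with values here, this is the same kind of change as the one from compound 1 to compound 3, but the place is not the same: there the methyl sits meta to a large group, here para to a large group.

Given that compound 2 gives 31 nM and that the measured step of a 1.1-fold higher number from compound 1 to compound 3 (0.04 log units; within the scatter) stayed within the scatter, the expected step is a 1.1-fold higher number from compound 2 to compound 4 (0.03 log units; within the scatter) in this assay. Compound 4 is therefore estimated at 33 nM, expected between 17 nM and 66 nM.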

Compound 4, half-maximal inhibitory concentration: 31 nM
The estimate for compound 4 lay 1.1-fold (0.03 log units) above the measured number, within the range that was stated.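

Methyl in place of bromo on an aromatic carbon reads in this assay as no change at the digits printed from compound 2 to compound 4 (within the scatter). Set beside the earlier step, the change carries across the two cores without a detectable difference: the same change on two cores in this assay, a 1.1-fold higher number (0.04 log units; within the scatter) from compound 1 to compound 3 and no change at the digits printed (within the scatter) from compound 2 to compound 4, 1.1-fold (0.04 log units) apart, within the scatter of two such steps

This shows that, for these two pairs, exchanging bromo for methyl leaves the number within the scatter at both places on the ring, but it does not establish a rule for other cores, other places or other assays. Since neither step moves beyond the scatter, the pairs also cannot tell whether bromo and methyl have any influence of their own on this read-out.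

The compounds shown leave open what a ring without any substituent would give, and how an amine or a carboxylic acid would read in the place of bromo or methyl. They also leave open whether a longer chain in place of the hydroxymethyl group would keep the numbers at this level.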